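This account rests on a few compounds, and the source may have more. Where it says the series, first, only, none or still open, it means among the compounds named here.

Measured compounds in a functional assay on C6 cells (Rattus norvegicus) for cytotoxicity, read by MTT assay, with a stated time of 24 h, tested at 100 ug/mL; a higher number here means a weaker effect of the compound at the concentration tested, a lower number a stronger effect:

compound 1, `O=C(CSc1nnnn1-c1ccccc1)N/N=c1/scc(-c2ccc(Br)cc2)n1-c1ccccc1`, gives 24.3%
compound 2, `O=C(CSc1nnnn1-c1ccccc1)N/N=c1/scc(-c2ccc(F)cc2)n1-c1ccccc1`, gives 35.8%

Compound 1 stands lowest of the two numbers shown, and the step from it to compound 2 is a number 11.5 percentage points higher from compound 1 to compound 2 (beyond the scatter) for fluoro in place of bromo on an aromatic carbon. Compound 3, `O=C(CSc1ncccn1)N/N=c1/scc(-c2ccc(Br)cc2)n1-c1ccccc1`, differs from compound 1 in another place: pyrimidin-2-yl in place of 1-phenyl-1H-tetrazol-5-yl on a sulfur. Within the data shown here, no measured step touches the sulfur; the single step from compound 1 to compound 2 concerns an aromatic carbon elsewhere in the shared core and gives no guide to a change at the sulfur. The expectation for compound 3 therefore rests on compound 1 alone, with a number 5.7 percentage points higher from compound 1 to compound 3 (within the scatter) expected as a step not beyond the scatter, but with wide uncertainty. In this assay compound 3 is estimated at 30%, with a range from 14% to 52%.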

Compound 3, a percentage reported as activity, at one concentration (the size of the read-out at that concentration, not a potency): 67.6%
The estimate for compound 3 lay 37.6 percentage points below the measured number, outside the stated range (above it).
By their numbers in this assay, from the lowest: compound 1; then compound 2; then compound 3.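

In this assay, the group on the sulfur proves to be a sensitive point in the structure: pyrimidin-2-yl in place of 1-phenyl-1H-tetrazol-5-yl gives a number 43.3 percentage points higher from compound 1 to compound 3 (beyond the scatter) and so a clearly weaker effect at the concentration tested. This step is much larger than the one on the aromatic carbon, where fluoro in place of bromo gives a number 11.5 percentage points higher from compound 1 to compound 2 (beyond the scatter). The change replaces two rings with one and alters the ring nitrogens together, and no measurement available here explains the step.

The compounds shown do not separate the part played by the phenyl ring from that of the tetrazole ring, which a 1-methyl-1H-tetrazol-5-yl group or a plain phenyl group on the sulfur could address. They also leave open whether the fluoro for bromo step would hold with pyrimidin-2-yl on the sulfur.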